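A few compounds are considered here, and "the series" means these few. Any claim that something is new, unique, unknown or untested is made for them only; others in the source may bear on it.

Three compounds share one core and are compared in a functional assay on HT-29 cells (Homo sapiens) for cytotoxicity, read by MTT assay, with a stated time of 24 h, tested at 32 ug/mL; on this read-out lower numbers stand for a weaker effect and higher numbers for a stronger effect at the one concentration tested. Compound 1 `Cn1c(-c2ccc(NC(=O)CCl)cc2)nc(-c2ccccc2)c1-c1ccccc1` carries a chloro on a saturated chain carbon bound to a carbonyl carbon; in this assay compound 1 gives 53.2%. Compound 2 `Cn1c(-c2ccc(NC(=O)CSc3nc4cc(Cl)ccc4o3)cc2)nc(-c2ccccc2)c1-c1ccccc1` gives 61.9%, and compound 3 `Cc1ccc2oc(SCC(=O)Nc3ccc(-c4nc(-c5ccccc5)c(-c5ccccc5)n4C)cc3)nc2c1` gives 59.5%. Among these three numbers compound 3 stands second highest. The steps leading to it are a number 2.4 percentage points lower from compound 2 to compound 3 (within the scatter) and a number 6.3 percentage points higher from compound 1 to compound 3 (within the scatter), and both lie within the scatter, so the three numbers cannot be told apart with confidence.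

Compound 4 `Cn1c(-c2ccc(NC(=O)CSc3nc4ccccc4s3)cc2)nc(-c2ccccc2)c1-c1ccccc1` has not been measured. It differs from compound 3 in one place: 1,3-benzothiazol-2-yl in place of 5-methyl-1,3-benzoxazol-2-yl on a sulfur. Among the compounds with values here, no measured step exchanges this whole group for another. The nearest evidence is the change on an aromatic carbon of the same group, a number 2.4 percentage points lower from compound 2 to compound 3 (within the scatter), together with the replacement of the chloro by either group, a number 8.7 percentage points higher from compound 1 to compound 2 (within the scatter) and a number 6.3 percentage points higher from compound 1 to compound 3 (within the scatter); every one of these stayed within the scatter. The expected step is therefore none beyond the scatter, a number 0.5 percentage points lower from compound 3 to compound 4 (within the scatter). For compound 4 the estimated result is 59%, with a range from 48% to 70%.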

Compound 4, a percentage reported as activity, at one concentration (the size of the read-out at that concentration, not a potency): 66%
For compound 4 the middle estimate is 7 percentage points below the measured one; the range from low to high includes it.
By their numbers in this assay, from the lowest: compounds 1, 3, 2 and 4 (each within the scatter of the next, the first and the last beyond it).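

Replacing the chloro on the saturated chain carbon with (1,3-benzothiazol-2-yl)sulfanyl gives, in this assay, a number 12.8 percentage points higher from compound 1 to compound 4 (beyond the scatter) and is the only replacement of that chloro shown here to pass beyond the scatter. The exchange on the sulfur itself separates nothing, since a number 6.5 percentage points higher from compound 3 to compound 4 (within the scatter) and a number 4.1 percentage points higher from compound 2 to compound 4 (within the scatter) both stay within the scatter, so 1,3-benzothiazol-2-yl cannot be told apart from 5-methyl-1,3-benzoxazol-2-yl or 5-chloro-1,3-benzoxazol-2-yl, and all three are accepted on this sulfur at the one concentration tested. No accompanying measurement offers an explanation for these results.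

The compounds shown leave open whether the fused ring pair matters at all, as a plain phenyl on the sulfur, or a carboxylic acid or an amine on the saturated chain carbon in its place, could give a similar or a very different number. They also leave open what a chloro or methyl on the 1,3-benzothiazol-2-yl group would do, and whether a longer chain between the sulfur and the carbonyl would keep the effect.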